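Diethylamino for dimethylamino on the shared core

The source may hold more compounds than are shown below. What is called first, only, known or untested is meant among the compounds shown, and "the series" means these compounds.

In a functional assay on NCI-H460 cells (Homo sapiens) for antiproliferative activity, read by MTT assay, with a stated time of 72 h (a lower number here means a stronger inhibitor, a higher number a weaker inhibitor), compound 1 `CN(C)CCn1cnnc1-c1cc(Oc2ccc(NC(=O)Nc3ccc(Cl)c(C(F)(F)F)c3)cc2F)ccn1` gives 1150 nM, the lowest of the three numbers. Compound 2 `CN(C)CCn1cnnc1-c1cc(Oc2ccc(NC(=O)Nc3cccc(C(F)(F)F)c3)cc2F)ccn1` gives 2150 nM and compound 3 `CN(C)CCn1cnnc1-c1cc(Oc2ccc(NC(=O)Nc3ccc(F)c(Cl)c3)cc2F)ccn1` gives 1580 nM; the steps of a 1.9-fold higher number from compound 1 to compound 2 (0.27 log units; within the scatter) and a 1.4-fold higher number from compound 1 to compound 3 (0.14 log units; within the scatter) both lie within the scatter, as does a 1.4-fold lower number from compound 2 to compound 3 (0.13 log units; within the scatter), so the three variants on the amide-type nitrogen are not separated by this assay. Compound 4 `CCN(CC)CCn1cnnc1-c1cc(Oc2ccc(NC(=O)Nc3ccc(Cl)c(C(F)(F)F)c3)cc2F)ccn1` differs from compound 1 by diethylamino in place of dimethylamino on a saturated chain carbon, two bonds along the chain from an aromatic nitrogen. Among the measured compounds shown here, no measured step touches the dimethylamino end of the chain; all three measured steps concern the other end of the molecule and none moves the number beyond the scatter. The expected step is therefore a 1.1-fold higher number from compound 1 to compound 4 (0.05 log units; within the scatter), with no direction assigned. Compound 4 is estimated at 1300 nM, range 500 nM to 3500 nM.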

Compound 4, half-maximal inhibitory concentration: 850 nM
Compound 4: middle estimate off by 1.5-fold (0.18 log units), on the high side, within the range that was stated.
By their numbers in this assay, from the lowest: compounds 4, 1, 3 and 2 (each within the scatter of the next, the first and the last beyond it).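

The only step shown at this end of the chain, a 1.4-fold lower number from compound 1 to compound 4 (0.13 log units; within the scatter), stays within the scatter. This position therefore accepts diethylamino, with 5 heavy atoms against 3 for dimethylamino, without a change that this assay can separate, as with the variants on the amide-type nitrogen. No measurement offered here bears on this result.

As far as these compounds go, whether a morpholine or a primary amine in place of diethylamino would move the number beyond the scatter remains open. The same holds for a longer chain between the amine and the shared core.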